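From dimethylamino to diisopropylamino on a carbonyl carbon

A few compounds are considered here, and "the series" means these few. Any claim that something is new, unique, unknown or untested is made for them only; others in the source may bear on it.

In a functional assay on HL-60 cells (Homo sapiens) for antiproliferative activity, read by MTT assay, with a stated time of 48 h (a higher number here means a weaker inhibitor, a lower number a stronger inhibitor), compound 1 `CC(C)=CCC[C@]1(C)/C=C/[C@@H](OC(=O)C=C(C)C)[C@](C)(O)/C=C/C(=O)/C(CN(C(C)C)C(C)C)=C\C1`, which carries (diisopropylamino)methyl on a double-bonded ring carbon, gives 740 nM. Compound 2 `CC[Si](CC)(CC)C/C1=C/C[C@](C)(CCC=C(C)C)/C=C/[C@@H](OC(=O)C=C(C)C)[C@](C)(O)/C=C/C1=O` holds a silicon-containing group there and gives 2810 nM. Compound 3 `CC(C)=CCC[C@]1(C)/C=C/[C@@H](OC(=O)C=C(C)C)[C@](C)(O)/C=C/C(=O)/C(C(=O)N(C)C)=C\C1`, with dimethylcarbamoyl in that place, gives 3340 nM. Compound 3 therefore has the highest number of the three, although the measurements cannot separate it from compound 2: a 1.2-fold higher number from compound 2 to compound 3 (0.08 log units; within the scatter).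

Compound 4 `CC(C)=CCC[C@]1(C)/C=C/[C@@H](OC(=O)C=C(C)C)[C@](C)(O)/C=C/C(=O)/C(C(=O)N(C(C)C)C(C)C)=C\C1` differs from compound 3 in one place: diisopropylamino in place of dimethylamino on a carbonyl carbon. In words, diisopropylamino stands in place of dimethylamino on a carbonyl carbon. Among the measured compounds shown here, no measured pair isolates this swap. The closest evidence is a 4.5-fold higher number from compound 1 to compound 3 (0.65 log units; beyond the scatter), but that step alters both the amino group and its link to the ring, and it cannot be divided between them. The other step, a 3.8-fold higher number from compound 1 to compound 2 (0.58 log units; beyond the scatter), removes the nitrogen group altogether and says little here. Compound 4 shares its diisopropylamino with compound 1 and its carbonyl with compound 3, so it may recover part of the gap between them, though not all of it. The expected change in this assay is small and towards a lower number: a 1.4-fold lower number from compound 3 to compound 4 (0.14 log units; within the scatter). Compound 4 is estimated at about 2400 nM, with an expected range from 800 nM to 6000 nM.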

Compound 4, half-maximal inhibitory concentration: 12700 nM
For compound 4 the middle estimate is 5.3-fold (0.72 log units) below the measured one; measured number outside the range, above it.
By their numbers in this assay, from the lowest: compound 1; then compounds 2 and 3 (each within the scatter of the next); then compound 4.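

In this assay, among the compounds shown here, the amino group on the carbonyl carbon clearly matters: diisopropylamino in place of dimethylamino gives a 3.8-fold higher number from compound 3 to compound 4 (0.58 log units; beyond the scatter) and so yields a weaker inhibitor, which no earlier pair could show. Diisopropylamino also does not bring the low number of compound 1 with it, since changing (diisopropylamino)methyl to diisopropylcarbamoyl on the double-bonded ring carbon gives a 17-fold higher number from compound 1 to compound 4 (1.23 log units; beyond the scatter) as the largest step in the set, while the change from the silicon-containing group of compound 2 gives a 4.5-fold higher number from compound 2 to compound 4 (0.66 log units; beyond the scatter) as well. Nothing measured here offers an explanation for these steps.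

The compounds shown leave open how the number moves with other amino groups on this carbonyl carbon, such as diethylamino or morpholine. They also leave open what (dimethylamino)methyl would give on the double-bonded ring carbon, a group that would complete the set of two amino groups on two kinds of link and show whether the amino swap runs the same way without the carbonyl.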